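A few compounds are considered here, and "the series" means these few. Any claim that something is new, unique, unknown or untested is made for them only; others in the source may bear on it.

Working notes on the series. Compound 1 `Cn1cc([N+](=O)[O-])cc1C(=O)NNC(=O)Nc1ccccc1`, compound 2 `COc1ccc(NC(=O)NNC(=O)c2cc([N+](=O)[O-])cn2C)cc1` and compound 3 `COc1ccc(NC(=O)NNC(=O)c2cc([N+](=O)[O-])c[nH]2)cc1` have been run in an ADME assay on Vero cells (Chlorocebus sabaeus) for cytotoxicity, read by MTT assay, with a stated time of 72 h; a lower number here means a stronger inhibitor, a higher number a weaker inhibitor. In this assay compound 1 gives 306000 nM. In this assay compound 2 gives 328000 nM. In this assay compound 3 gives 401000 nM. The three numbers all sit within the scatter of one another.

Two single changes connect the measured compounds. From compound 2 to compound 1 the change is hydrogen in place of methoxy on an aromatic carbon, and the step in this assay is a 1.1-fold lower number from compound 2 to compound 1 (0.03 log units; within the scatter). From compound 2 to compound 3 the change is hydrogen in place of methyl on an aromatic nitrogen; this is also how the core of compound 2 differs from the core of compound 3, and the step in this assay is a 1.2-fold higher number from compound 2 to compound 3 (0.09 log units; within the scatter). For compounds 1 and 3 only the two values are known, and they lie within the scatter of each other.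

Compound 4 `O=C(NNC(=O)c1cc([N+](=O)[O-])c[nH]1)Nc1ccccc1` has not been measured yet. It differs from compound 3 by hydrogen in place of methoxy on an aromatic carbon. This is the same change as from compound 2 to compound 1, now made on the core of compound 3, and the place is described in the same words for both; the change occurs twice in the set. Because a 1.1-fold lower number from compound 2 to compound 1 (0.03 log units; within the scatter) stayed within the scatter, a step of similar size is expected from compound 3 to compound 4 in this assay, namely a 1.1-fold lower number from compound 3 to compound 4 (0.03 log units; within the scatter). Compound 4 is therefore expected near 375000 nM, estimated to fall between 230000 nM and 620000 nM.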

Compound 4, half-maximal inhibitory concentration: 357000 nM
Compound 4: the middle estimate sits 1.1-fold (0.02 log units) above what was measured; the measured number falls inside the stated range.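

In this assay, hydrogen in place of methoxy on an aromatic carbon gives a 1.1-fold lower number from compound 3 to compound 4 (0.05 log units; within the scatter), and this step matches the earlier one on the other core: the same change on two cores in this assay, a 1.1-fold lower number (0.03 log units; within the scatter) from compound 2 to compound 1 and a 1.1-fold lower number (0.05 log units; within the scatter) from compound 3 to compound 4, 1.0-fold (0.02 log units) apart, within the scatter of two such steps.
Hydrogen in place of methyl on an aromatic nitrogen gives a 1.2-fold higher number from compound 1 to compound 4 (0.07 log units; within the scatter), and this step likewise matches its earlier counterpart: the same change on two cores in this assay, a 1.2-fold higher number (0.09 log units; within the scatter) from compound 2 to compound 3 and a 1.2-fold higher number (0.07 log units; within the scatter) from compound 1 to compound 4, 1.0-fold (0.02 log units) apart, within the scatter of two such steps.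
Among the compounds shown here, each change therefore reads the same on both cores, with no sign in these four compounds that the outcome of one change depends on the other, but every step lies within the scatter, so this shows only that neither change separates from the noise in this assay, not that either has a measurable effect of its own, and nothing here extends to other cores or other read-outs.

The compounds shown leave open whether a group of a different kind on the aromatic carbon para to a large group, such as an amine or a carboxylic acid, would give a step beyond the scatter. As far as these compounds go, it also remains open whether a longer chain such as propyl on the aromatic nitrogen, in place of methyl, would still leave the number where these four compounds sit.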